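This account rests on a few compounds, and the source may have more. Where it says the series, first, only, none or still open, it means among the compounds named here.

Compound 2 `COC(=O)c1cc(NCc2ccccc2[N+](=O)[O-])c2cn[nH]c2c1` stands highest of the two numbers in an assay for inhibition of Indoleamine 2,3-dioxygenase 1 (Homo sapiens), with stated times of 10 min and 60 min, tested at 100 uM (on this read-out lower numbers stand for a weaker effect and higher numbers for a stronger effect at the one concentration tested), where compound 2 gives 47%. For the measured compounds named here, compound 1 `N#Cc1cc(NCc2ccccc2[N+](=O)[O-])c2cn[nH]c2c1` gives 17% in this assay, and the one step between them, a number 30 percentage points higher from compound 1 to compound 2 (beyond the scatter), came from a change at the same aromatic carbon. Compound 3 `O=[N+]([O-])c1ccccc1CNc1cc(Br)cc2[nH]ncc12` differs from compound 2 as follows: bromo in place of methoxycarbonyl on an aromatic carbon. Going by the values given here, no measured step involves bromo, so only the size of the earlier swap guides the expectation: a drop of comparable size, well beyond the scatter. Compound 3 is therefore expected to give 25%, between 5% and 50%. The expected step is a number 22 percentage points lower from compound 2 to compound 3 (beyond the scatter).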

Compound 3, a percentage reported as inhibition, at one concentration (the size of the read-out at that concentration, not a potency): 83%
Compound 3: the middle estimate sits 58 percentage points below what was measured, and the stated range ends below it.
By their numbers in this assay, from the lowest: compound 1; then compound 2; then compound 3.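

Swapping methoxycarbonyl for the single atom of bromo gives a number 36 percentage points higher from compound 2 to compound 3 (beyond the scatter) in this test, and swapping cyano for bromo gives a number 66 percentage points higher from compound 1 to compound 3 (beyond the scatter) as well, so bromo stands highest of the three groups at this aromatic carbon. The first pair alone could have suggested that the larger group does better here, but bromo, with fewer heavy atoms than methoxycarbonyl, goes against that. The compounds shown offer no evidence on why bromo gives the higher number.

As far as these compounds go, whether chloro or an amine at this carbon would match bromo remains open.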